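The compounds below may be only part of what the source reports. "The series", "measured", "known", "first", "only" and "open" are said of these compounds alone.

Measured so far:
Compound 1 `COc1ccc(C2N=C(SCc3ccc(Cl)cc3)NC(C)=C2C(=O)Nc2ccc(F)cc2)cc1OC` gives 10.3% in a functional assay on the whole organism (artery, strain albino) with Rattus norvegicus as the target, with a stated time of 60 min, at a dose of 10 mg/kg by the oral route; a higher number here means more inhibition at the dose given (going by the name of the read-out), a lower number less inhibition.
Compound 2 `CC1=C(C(=O)Nc2ccc([N+](=O)[O-])cc2)C(c2ccc(Br)cc2)N=C(SCc2ccccc2Cl)N1` gives 6.7% in this assay.
Compound 3 `CC1=C(C(=O)Nc2ccc([N+](=O)[O-])cc2)C(c2cccc([N+](=O)[O-])c2)N=C(SCc2ccccc2Cl)N1` gives 6.7% in this assay.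

Compound 3 sits level with compound 2 at the digits shown, the two together the lowest of the three numbers; compound 1 lies higher only within the scatter. Going by the values given here, the single one-place step recorded, no change at the digits printed from compound 2 to compound 3 (within the scatter), brought no change. Compound 4 `CC1=C(C(=O)Nc2ccc([N+](=O)[O-])cc2)C(c2cccc([N+](=O)[O-])c2)N=C(SCc2ccc(F)cc2)N1` differs from compound 3 by 4-fluorophenyl in place of 2-chlorophenyl on a saturated chain carbon bound to a sulfur. Among the compounds with values here, no measured pair isolates a change at this position; compound 1 differs from compound 3 at several places at once, so its value cannot be read as a step. With nothing to point either way, the expected shift in this assay is a number 1.3 percentage points higher from compound 3 to compound 4 (within the scatter), none beyond the scatter. Compound 4 is estimated at 8% in this assay, range 1% to 17%.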

Compound 4, a percentage reported as inhibition, in the whole organism at one dose (the size of the read-out at that dose, not a potency): 7.2%
For compound 4 the middle estimate is 0.8 percentage points above the measured one; the range from low to high includes it.
By their numbers in this assay, from the lowest: compounds 2, 3, 4 and 1 (each within the scatter of the next).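

In this assay, going by these compounds alone, the step of a number 0.5 percentage points higher from compound 3 to compound 4 (within the scatter) gives the first direct reading on the saturated chain carbon bound to a sulfur: 4-fluorophenyl in place of 2-chlorophenyl leaves the inhibition at the dose given within the scatter. This single step changes both the halogen and its place on the ring, and it cannot separate the two. No measured evidence bears on this result. Still open, as far as these compounds go, is whether a carboxylic acid on this ring, or an amine or longer chain in place of the 4-fluorobenzyl group, would move the number beyond the scatter.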